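This account rests on a few compounds, and the source may have more. Where it says the series, first, only, none or still open, it means among the compounds named here.

Within the data shown here, compound 2 `C=C1CCC[C@]2(C)CCC(c3cn(-c4ccccc4C(C)=O)nn3)=CC[C@@]12C` holds the lower of the two numbers so far in a functional assay on MCF7 cells (Homo sapiens) for cytotoxicity, read by MTT assay, with a stated time of 48 h (a lower number here means a stronger inhibitor, a higher number a weaker inhibitor), at 29900 nM while compound 1 `C=C1CCC[C@]2(C)CCC(c3cn(-c4ccc(I)cc4)nn3)=CC[C@@]12C` reads 162000 nM on the same core. The next compound is compound 3 `C=C1CCC[C@]2(C)CCC(c3cn(-c4ccc(C)cc4)nn3)=CC[C@@]12C` with 4-methylphenyl in place of 2-acetylphenyl on an aromatic nitrogen at the same place. Among the measured compounds shown here, one measured step bears on this change: a 5.4-fold lower number from compound 1 to compound 2 (0.73 log units; beyond the scatter) for 2-acetylphenyl in place of 4-iodophenyl on that nitrogen. That single step is modest and gives no trend. Compound 3 gives up 2-acetylphenyl, so a move back towards compound 1 is expected, though probably not all the way. The estimate means a 2.7-fold higher number from compound 2 to compound 3 (0.43 log units; beyond the scatter) as the expected move towards a higher number, and it could prove small. For compound 3 the expected value is 80000 nM with an estimated range from 28000 nM to 200000 nM in these notes.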

Compound 3, half-maximal inhibitory concentration: 54900 nM
Compound 3: middle estimate off by 1.5-fold (0.16 log units), on the high side; the measured number falls inside the stated range.
By their numbers in this assay, from the lowest: compounds 2 and 3 (each within the scatter of the next); then compound 1.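

On the aromatic nitrogen of the five-membered ring, this assay gives a 1.8-fold higher number from compound 2 to compound 3 (0.26 log units; within the scatter), so 2-acetylphenyl and 4-methylphenyl cannot be told apart at this position, even though 4-methylphenyl has no hydrogen-bond acceptor. The other new step is a 3.0-fold lower number from compound 1 to compound 3 (0.47 log units; beyond the scatter) for methyl in place of iodo on an aromatic carbon, which shows that the gap from compound 1 is not confined to 2-acetylphenyl. No measurement among these compounds accounts for either step. Compounds 2 and 3 differ in both the group and where it sits on the phenyl ring, so the contribution of each remains unresolved. Also open, from the compounds shown here alone, is how an amine or a carboxylic acid on that phenyl ring would compare with methyl and acetyl on the shared core.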